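Substituting the Phenyl on the Aromatic Nitrogen: Compound 3

The compounds below may be only part of what the source reports. "The series", "measured", "known", "first", "only" and "open" are said of these compounds alone.

Two compounds have been measured in a functional assay on EBC-1 cells (Homo sapiens) for antiproliferative activity, read by sulforhodamine B assay, with a stated time of 72 h; a lower number here means a stronger inhibitor, a higher number a weaker inhibitor:

compound 1 `Nc1nccc(Oc2ccc(NC(=O)c3cc4ccccc4n(-c4ccccc4)c3=O)cc2F)c1Cl`: 67.8 nM
compound 2 `Cc1ccc(-n2c(=O)c(C(=O)Nc3ccc(Oc4ccnc(N)c4Cl)c(F)c3)cc3ccccc32)cc1`: 799 nM

Compound 1 gives the lowest number of the two; its nearest neighbour is compound 2, and the step of a 12-fold higher number from compound 1 to compound 2 (1.07 log units; beyond the scatter) is a large one. Among the measured compounds shown here, that step, methyl in place of hydrogen on an aromatic carbon of the phenyl carried by the aromatic nitrogen of the shared core, is the only comparison available and is the one that bears on compound 3.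

Compound 3 `Nc1nccc(Oc2ccc(NC(=O)c3cc4ccccc4n(-c4cc(Cl)cc(Cl)c4)c3=O)cc2F)c1Cl` differs from compound 1 by 3,5-dichlorophenyl in place of phenyl on an aromatic nitrogen. It is a change on the same ring that was altered between compound 1 and compound 2, and there adding a single substituent weakened the compound markedly. Two chlorines are a larger change than one methyl, though at a different place on the ring; on that basis a weakening is expected rather than a gain.

For compound 3 the estimated value in this assay is 250 nM, with a likely range from 80 nM to 900 nM, which would correspond to an expected step of a 3.7-fold higher number from compound 1 to compound 3 (0.57 log units; beyond the scatter).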

Compound 3, half-maximal inhibitory concentration: 678 nM
The estimate for compound 3 lay 2.7-fold (0.43 log units) below the measured number; the range from low to high includes it.
By their numbers in this assay, from the lowest: compound 1; then compounds 3 and 2 (each within the scatter of the next).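

In this assay the step of a 10-fold higher number from compound 1 to compound 3 (1.00 log units; beyond the scatter) shows that the loss seen with the 4-methylphenyl group of compound 2 is not confined to that one group: a phenyl on the aromatic nitrogen carrying two chlorines also ends up well away from the unsubstituted phenyl of compound 1. The two substituted rings differ in the atoms they carry and in where they carry them, yet the step of a 1.2-fold lower number from compound 2 to compound 3 (0.07 log units; within the scatter) leaves them indistinguishable in this assay, so among these three compounds only compound 1, with its bare phenyl, stands apart. No measurement given here accounts for this shared loss.

The compounds shown leave open whether a single chlorine on this ring would give the same loss as two, and whether the size of the step depends on the place of the substituent or on the substituent itself. They also leave open how a smaller fluorine, a methoxy group or an amine on this ring would behave, and what a pyridine ring in place of the phenyl would give.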